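The source may hold more compounds than are shown below. What is called first, only, known or untested is meant among the compounds shown, and "the series" means these compounds.

Compound 1 `COc1cc(-c2cc(/C=C/C(=O)c3ccc(N)cc3)[nH]n2)cc(OC)c1OC` — 94%
Compound 2 `COc1ccc(-c2cc(/C=C/C(=O)c3ccc(OC)c(OC)c3)[nH]n2)cc1` — 84%

In a functional assay on U-251 cells (Homo sapiens) for cytotoxicity, read by sulforhodamine B assay, with a stated time of 48 h, tested at 0.1 uM (on this read-out higher numbers stand for a weaker effect at the one concentration tested and lower numbers for a stronger effect), compound 1 gives 94%. Compound 2 gives 84% in this assay, and the two numbers lie within the usual scatter of each other, so the data do not separate them. Both show a weak effect at the single concentration tested.

Compound 3 `COc1cc(-c2cc(/C=C/C(=O)c3ccc(Cl)c(Cl)c3)[nH]n2)cc(OC)c1OC` has not yet been measured in this assay. It differs from compound 1 in one place: 3,4-dichlorophenyl in place of 4-aminophenyl on a carbonyl carbon. Going by the values given here, no measured pair in this set isolates such a change, so there is nothing here to calibrate it. With both measured compounds sitting close together, the expected step from compound 1 to compound 3 in this assay is small, a number 6 percentage points lower from compound 1 to compound 3 (within the scatter), and not beyond the scatter in either direction. Compound 3 is therefore estimated to give about 88% in this assay, expected to fall between 72% and 100%.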

Compound 3, a percentage reported as activity, at one concentration (the size of the read-out at that concentration, not a potency): 95%
Compound 3: the middle estimate sits 7 percentage points below what was measured; measured number inside the range.
By their numbers in this assay, from the lowest: compounds 2, 1 and 3 (each within the scatter of the next, the first and the last beyond it).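

In this assay, going by these compounds alone, placing 3,4-dichlorophenyl in place of 4-aminophenyl on a carbonyl carbon gives a number 1 percentage points higher from compound 1 to compound 3 (within the scatter) and provides the first comparison here of compounds that differ in one place. At this position, the exchange of a group with a hydrogen-bond donor and acceptor for one with two chlorine atoms and neither of those counts does not separate the two compounds at the single concentration tested. Nothing measured here offers an explanation for this result.

Going by these compounds, whether a carboxylic acid or a dimethylamino group on the same phenyl ring would shift the read-out at this position remains open. So does whether compound 1 and compound 3 would stay together at higher concentrations, which a single concentration cannot show.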